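Methoxy step on a second core of the amide series

The compounds below may be only part of what the source reports. "The series", "measured", "known", "first", "only" and "open" are said of these compounds alone.

Compound 1 `CC/C(=C(\c1ccccc1)c1ccc(NC(=O)C(C)C)cc1)c1ccc(Cl)cc1Cl` and compound 2 `CC/C(=C(/c1ccc(NC(=O)C(C)C)cc1)c1ccc(OC)cc1)c1ccc(Cl)cc1Cl` share one core; compound 3 `CC/C(=C(/c1ccccc1)c1ccc(NC(=O)C(C)C)cc1)c1ccc(OCc2ccccc2)cc1` and the unmeasured compound 4 `CC/C(=C(\c1ccc(NC(=O)C(C)C)cc1)c1ccc(OC)cc1)c1ccc(OCc2ccccc2)cc1` share another. The difference between the two cores is not broken down here. In a functional assay on MCF7 cells (Homo sapiens) for inhibition, read by trypan blue exclusion, with a stated time of 72 h (a higher number here means a weaker inhibitor of growth, a lower number a stronger inhibitor of growth), compound 1 gives 8300 nM. In this assay compound 2 gives 6600 nM. The change between them is methoxy in place of hydrogen on an aromatic carbon, and it produced a 1.3-fold lower number from compound 1 to compound 2 (0.10 log units; within the scatter), so the two values cannot be told apart.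

Compound 3 reaches only a limit of this assay, reported as > 30000 nM; the same limit appears in the limit of > 30000 nM in this assay, at which 1 of the 3 values shown sits.

Compound 4 carries the same change on the other core, (methoxy in place of hydrogen on an aromatic carbon), with the place described in the same words as for compound 2, so it is the same change. Going by the values given here, the only measured guide is the pair of compound 1 and compound 2, where the step stayed within the scatter, and the starting point is a limit rather than a number, so no movement of compound 4 away from that limit is expected. The expected step is a step that the limit leaves unreadable from compound 3 to compound 4, because the measured counterpart a 1.3-fold lower number from compound 1 to compound 2 (0.10 log units; within the scatter) lies within the scatter. For compound 4 in this assay the estimate is 35000 nM, with a likely range from 15000 nM to 80000 nM, and a limit rather than a number is the more probable outcome.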

Compound 4, concentration for 50% growth inhibition: > 30000 nM
Compound 4: a limit, no number; the forecaster's own chance of this, stated with the estimate: 65%; the middle value is on the limit's open side.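

In this assay compound 4 gives > 30000 nM as a limit and not a number. With compound 3 also at a limit, the methoxy step from compound 3 to compound 4 cannot be read. The compounds shown leave open whether methoxy in place of hydrogen on this core changes growth inhibition at all, and the two compounds share one limit: the limit of > 30000 nM in this assay, at which 2 of the 4 values shown sit.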